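The source may report more compounds than this note shows. Statements on the series, on what has been measured and on what is new or still open speak of the compounds shown alone.

Series notes. Compound 2 `CCOC(=O)c1c(-c2cccc(Oc3ccccc3)c2)[nH]c2cc(OC)ccc2c1=O` carries a phenoxy group on the pendant aromatic ring. In an ADME assay on HEK293 cells (Homo sapiens) for cytotoxicity, read by luminescence, with a stated time of 72 h (on this read-out lower numbers stand for an effect already at smaller amounts and higher numbers for an effect only at larger amounts of compound), compound 2 returns only a limit, > 22000 nM, and no number. Compound 1 `CCOC(=O)c1c(-c2cccc(OCC)c2)[nH]c2cc(OC)ccc2c1=O` bears an ethoxy group instead. In this assay compound 1 likewise stops at a limit, > 22000 nM. Compound 3 `CCOC(=O)c1c(-c2cccc(F)c2)[nH]c2cc(OC)ccc2c1=O` carries fluoro instead. In this assay compound 3 also gives a limit, > 22000 nM. The steps within the measured set are therefore all unreadable: a step that the two limits leave unreadable from compound 1 to compound 2, a step that the two limits leave unreadable from compound 1 to compound 3 and a step that the two limits leave unreadable from compound 2 to compound 3 cannot be sized, since the limit of > 22000 nM in this assay, at which 3 of the 3 values shown sit, caps every value shown. Compound 2 thus stands with the other two at the limit, with no ranking possible among the three.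

Compound 4 `CCOC(=O)c1c(-c2cccc(CO)c2)[nH]c2cc(OC)ccc2c1=O` is the next member: hydroxymethyl in place of phenoxy on an aromatic carbon. Among the compounds with values here, the three steps above concern the same ring but none of them can be read, so no measured step gives a size for this change. Because the limit of > 22000 nM in this assay, at which 3 of the 3 values shown sit, holds for all three measured values, the step from compound 2 to compound 4 is expected to be a step that the limit leaves unreadable from compound 2 to compound 4, with compound 4 most likely reported again only as a limit. Compound 4 is expected near 30000 nM, in a range from 15000 nM to 100000 nM.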

Compound 4, half-maximal effective concentration: > 22000 nM
Compound 4 ended at the assay's limit; the forecaster's own chance of this, stated with the estimate: 80%; the middle value does not contradict the limit.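

In this assay compound 4 gives only a limit, > 22000 nM, and not a number. No step linking compound 4 with compound 1, compound 2 or compound 3 can be read, because of one shared bound: the limit of > 22000 nM in this assay, at which 4 of the 4 values shown sit.

The compounds shown leave open whether any of these four compounds has a measurable effect in this assay, and how the groups on the pendant ring would rank.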